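The source may hold more compounds than are shown below. What is called first, only, known or untested is meant among the compounds shown, and "the series" means these compounds.

Working notes on the series. In a functional assay on K562 cells (Homo sapiens) for cytotoxicity, read by MTT assay, with a stated time of 72 h (on this read-out higher numbers stand for weaker inhibition and lower numbers for stronger inhibition), compound 1 (`CC(C)(C)NC(=S)N/N=C1\CC(c2ccc(O)cc2)Oc2cc(O)ccc21`) gives 8900 nM. Compound 2 (`CCCN(CCC)C(=S)N/N=C1\CC(c2ccc(O)cc2)Oc2cc(O)ccc21`) gives 12400 nM. Compound 1 is therefore not separated from compound 2 on the two numbers available.

Compound 3 (`Oc1ccc(C2C/C(=N\NC(=S)N3CCCCC3)c3ccc(O)cc3O2)cc1`) has not yet been measured. It carries piperidin-1-yl in place of (tert-butyl)amino on a thiocarbonyl carbon. Among the compounds with values here, the one measured step that bears on this change is a 1.4-fold higher number from compound 1 to compound 2 (0.14 log units; within the scatter). That step puts dipropylamino in place of the same (tert-butyl)amino on the same thiocarbonyl carbon, so it is the closest available guide. It is a single step, however, and no group containing a ring has been measured at this place.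

In this assay, no change beyond the scatter is therefore expected for compound 3. The expected step is a 1.2-fold higher number from compound 1 to compound 3 (0.07 log units; within the scatter). For compound 3, the estimated value is 10500 nM, with an expected range from 5000 nM to 22000 nM.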

Compound 3, half-maximal inhibitory concentration: 13700 nM
Compound 3: the middle estimate sits 1.3-fold (0.12 log units) below what was measured; the measured number falls inside the stated range.
By their numbers in this assay, from the lowest: compounds 1, 2 and 3 (each within the scatter of the next).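

In this assay, within the data shown here, piperidin-1-yl is the first group containing a ring at this place, on a thiocarbonyl carbon, and it gives a 1.5-fold higher number from compound 1 to compound 3 (0.19 log units; within the scatter) and a 1.1-fold higher number from compound 2 to compound 3 (0.04 log units; within the scatter). The ring therefore separates compound 3 from neither the (tert-butyl)amino nor the dipropylamino compound, so all three compounds stay within the scatter of one another. The exchange of (tert-butyl)amino, with 1 hydrogen-bond donor, for piperidin-1-yl, with 0 hydrogen-bond donors, likewise comes with no change beyond the scatter, and nothing available accounts for this result.

The compounds shown leave open whether this tolerance extends to groups of another kind at this place, such as morpholin-4-yl, with a second hetero atom in the ring, or phenylamino, with an aromatic ring, or to a longer chain such as dihexylamino. They also leave open whether any group on this thiocarbonyl carbon can move the number beyond the scatter, since the three groups compared so far are all built from carbon and a single nitrogen.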